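Swapping Bromo for Chloro on the Carbonyl-Bearing Ring

A few compounds are considered here, and "the series" means these few. Any claim that something is new, unique, unknown or untested is made for them only; others in the source may bear on it.

Compound 1 `COc1ccc(/C=C(/SCc2ccc(Cl)cc2)C(=O)c2ccc(Br)cc2)cc1` was examined in a functional assay on DU-145 cells (Homo sapiens) for inhibition, read by trypan blue exclusion, with a stated time of 96 h (a lower number here means a stronger inhibitor of growth, a higher number a weaker inhibitor of growth), where compound 1 gives 10000 nM. Compound 3 `O=C(/C(=C\c1cccc(Cl)c1Cl)SCc1ccc(Cl)cc1)c1ccc(Br)cc1` gives 10000 nM in this assay, and the step of no change at the digits printed from compound 1 to compound 3 (within the scatter) leaves the two level, so that compound 1 and compound 3 together hold the lowest of the three numbers. Going by the values given here, compound 2 `COc1ccc(/C=C(/SCc2ccc(F)cc2)C(=O)c2ccc(Br)cc2)cc1` gives 50000 nM, and the step of a 5.0-fold higher number from compound 1 to compound 2 (0.70 log units; beyond the scatter) is the only change of one halogen for another among the measured pairs; it is modest in size.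

Compound 4 `COc1ccc(/C=C(/SCc2ccc(Cl)cc2)C(=O)c2ccc(Cl)cc2)cc1` differs from compound 1 by chloro in place of bromo on an aromatic carbon. Among the compounds with values here, no measured step touches this ring, so the halogen exchange from compound 1 to compound 2, which sits on a different ring and runs from chloro to fluoro rather than from bromo to chloro, is the nearest guide, and it points to a small effect at most. On that footing the step from compound 1 to compound 4 is expected to be slight, leaning toward a somewhat higher number: a 1.5-fold higher number from compound 1 to compound 4 (0.18 log units; within the scatter). Compound 4 is therefore estimated at 15000 nM in this assay, with a range from 5000 nM to 50000 nM.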

Compound 4, concentration for 50% growth inhibition: 10000 nM
Beside the measured number, compound 4's estimate is 1.5-fold (0.18 log units) above it; low and high end bracket the measured number.
By their numbers in this assay, from the lowest: compounds 1, 3 and 4 (each within the scatter of the next); then compound 2.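

In this assay, going by these compounds alone, the change from (4-bromophenyl)carbonyl to (4-chlorophenyl)carbonyl gives no change at the digits printed from compound 1 to compound 4 (within the scatter) and provides the first reading of a change at this place, as the earlier steps touched other parts of the shared core. This exchange of one halogen for another lies within the scatter, whereas the exchange of fluoro for chloro elsewhere gives a 5.0-fold higher number from compound 1 to compound 2 (0.70 log units; beyond the scatter) and lies beyond it. Those two steps differ in both their place and their halogens, so they cannot separate the effect of where the exchange occurs from the effect of which halogens are involved, and nothing at hand offers an explanation for either result.

As far as these compounds go, what an amine, a carboxylic acid or a methoxy group would do in place of the halogen on this ring remains open. From the compounds shown here alone, it is also open whether chloro in place of bromo would read the same alongside the 2,3-dichlorophenyl group of compound 3, or alongside the fluoro of compound 2.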